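A few compounds are considered here, and "the series" means these few. Any claim that something is new, unique, unknown or untested is made for them only; others in the source may bear on it.

In a functional assay on MCF7 cells (Homo sapiens) for inhibition, read by MTT assay, with a stated time of 72 h (a lower number here means a stronger inhibitor, a higher number a weaker inhibitor), compound 2 `COc1cc(NC(C)CCCNC(=O)Nc2ccc(Br)cc2)c2ncccc2c1` gives 2600 nM, the lowest of the three numbers and the strongest inhibitor of this small set: compound 1 `COc1cc(NC(C)CCCNC(=O)Nc2cccc(Cl)c2)c2ncccc2c1` gives 11000 nM and compound 3 `COc1cc(NC(C)CCCNC(=O)Nc2cccc(O)c2)c2ncccc2c1` gives 11000 nM. The steps of a 4.2-fold lower number from compound 1 to compound 2 (0.63 log units; beyond the scatter) and a 4.2-fold higher number from compound 2 to compound 3 (0.63 log units; beyond the scatter) are the only ones beyond the scatter, and both merely vary a substituent on the same phenyl. Among the measured compounds shown here, compound 4 `COc1cc(NC(C)CCCNC(=O)NNC(=O)Nc2cccc(F)c2)c2ncccc2c1` differs from compound 2 by ((3-fluorophenyl)carbamoyl)amino in place of 4-bromophenyl on an amide-type nitrogen, a change of a different kind that no measured step covers, so the expectation rests loosely on them. A step towards a higher number, of roughly the size seen so far, is expected at a 3.5-fold higher number from compound 2 to compound 4 (0.54 log units; beyond the scatter). Compound 4 is therefore estimated at 9000 nM, within 3000 nM to 30000 nM.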

Compound 4, half-maximal inhibitory concentration: 150 nM
Beside the measured number, compound 4's estimate is 60-fold (1.78 log units) above it, and the stated range ends above it.
By their numbers in this assay, from the lowest: compound 4; then compound 2; then compounds 1 and 3 (each within the scatter of the next).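

In this assay, ((3-fluorophenyl)carbamoyl)amino in place of the aryl group on this amide-type nitrogen gives a 17-fold lower number from compound 2 to compound 4 (1.24 log units; beyond the scatter) and a 73-fold lower number from compound 3 to compound 4 (1.87 log units; beyond the scatter) and a 73-fold lower number from compound 1 to compound 4 (1.87 log units; beyond the scatter) as steps, all larger than any step among the simple substituted phenyls. The position therefore admits a far larger gain than exchanging substituents on the phenyl had shown. Nothing measured here accounts for this gain.

From the compounds shown here alone, whether the gain follows the added carbamoylamino link or the fluorine on the ring stays open. Also open, going by these compounds, is whether a longer chain or a terminal amine at this nitrogen would behave alike.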